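This account rests on a few compounds, and the source may have more. Where it says the series, first, only, none or still open, it means among the compounds named here.

Measured compounds in a functional assay on NCI-H23 cells (Homo sapiens) for antiproliferative activity; a higher number here means a weaker inhibitor of growth, a lower number a stronger inhibitor of growth:
- compound 1 `COc1ccccc1CN1CC=C(CCC(=O)NO)C1=O`: 6130 nM
- compound 2 `COc1ccc(CN2CC=C(CCC(=O)NO)C2=O)cc1`: 1640 nM
- compound 3 `O=C(CCC1=CCN(Cc2cccc(C(F)(F)F)c2)C1=O)NO`: 680 nM

Compound 3 stands at the lowest of the three numbers in this assay. Compound 2 is nearest, with a higher number, and that gap is beyond the scatter of repeat measurements; compound 1 is furthest, with a higher number, again beyond the scatter. Going by the values given here, no two of the measured compounds differ in only one place, so no single-change step between them can be read off. Within these three, the substituent on the benzyl ring is the only point of variation, and the trifluoromethyl of compound 3 goes with the strongest growth inhibition seen so far.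

The next compound, compound 4 `O=C(CCC1=CCN(Cc2ccccc2)C1=O)NO`, is compound 3 with the change (hydrogen in place of trifluoromethyl on an aromatic carbon), that is, hydrogen in place of trifluoromethyl on an aromatic carbon. Among the compounds with values here, no measured pair shows this change, so the step can only be guessed from the spread of the series. Because compound 2 gives 1640 nM and compound 1 gives 6130 nM, both with a substituted benzyl and both weaker than compound 3, the unsubstituted benzyl of compound 4 is expected to fall among the weaker members rather than below compound 3. The step from compound 3 to compound 4 is expected to be a loss, a 2.6-fold higher number from compound 3 to compound 4 (0.42 log units; beyond the scatter), beyond the scatter. Compound 4 is thus estimated at 1800 nM, within a range of 600 nM to 5500 nM.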

Compound 4, concentration for 50% growth inhibition: 4290 nM
The estimate for compound 4 lay 2.4-fold (0.38 log units) below the measured number, and the stated range covers the measured number.
By their numbers in this assay, from the lowest: compound 3; then compound 2; then compounds 4 and 1 (each within the scatter of the next).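

Hydrogen in place of trifluoromethyl, on an aromatic carbon meta to a large group, gives the first direct reading at this place in this assay: a 6.3-fold higher number from compound 3 to compound 4 (0.80 log units; beyond the scatter). This ties the stronger growth inhibition of compound 3 to the trifluoromethyl itself, with compound 4 now serving as the unsubstituted reference for the benzyl ring. Against that reference, the methoxy of compound 2 stands apart, with a 2.6-fold higher number from compound 2 to compound 4 (0.42 log units; beyond the scatter), whereas the methoxy of compound 1 does not, with a 1.4-fold lower number from compound 1 to compound 4 (0.16 log units; within the scatter), so a methoxy on the ring does not by itself separate a compound from compound 4, and no measured property in hand accounts for any of these steps.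

Still open, as far as these compounds go, is whether the gain is particular to trifluoromethyl or extends to other groups on the same aromatic carbon, such as a chlorine atom, a methyl, a nitrile, an amine or a carboxylic acid. The compounds shown also leave open how trifluoromethyl behaves on the other carbons of the ring, and whether two substituents on the ring would add to each other.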